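A Rearranged Side Chain on the Shared Core

This account rests on a few compounds, and the source may have more. Where it says the series, first, only, none or still open, it means among the compounds named here.

Among the compounds with values here, in a functional assay on DU-145 cells (Homo sapiens) for cytotoxicity, read by MTT assay (a lower number here means a stronger inhibitor, a higher number a weaker inhibitor), compound 3 (`CC[C@](C)(O)CC(=O)O[C@H](CC=C(C)C)C1=CC(=O)c2c(O)ccc(O)c2C1=O`) gives 20500 nM, the lowest of three numbers so far. Compound 1 (`CCCCC(O)CC(=O)O[C@H](CC=C(C)C)C1=CC(=O)c2c(O)ccc(O)c2C1=O`) gives 45300 nM and compound 2 (`COCCO[C@H](CC=C(C)C)C1=CC(=O)c2c(O)ccc(O)c2C1=O`) gives 43200 nM. Compound 4 (`CCC(CO[C@H](CC=C(C)C)C1=CC(=O)c2c(O)ccc(O)c2C1=O)OC(C)=O`) has the same atoms as compound 3, joined differently: 2-acetoxybutyl in place of (2-hydroxy-2-methylbutyl)carbonyl on an oxygen on a saturated carbon. Of the measured changes at that oxygen, the closest is a 2.1-fold lower number from compound 2 to compound 3 (0.32 log units; beyond the scatter), since 2-methoxyethyl most resembles the incoming 2-acetoxybutyl. Similar in size is a 2.2-fold lower number from compound 1 to compound 3 (0.34 log units; beyond the scatter), while a 1.0-fold lower number from compound 1 to compound 2 (0.02 log units; within the scatter). A modest move back up is therefore expected, a 2.0-fold higher number from compound 3 to compound 4 (0.31 log units; beyond the scatter). For compound 4, the expected value is 42000 nM, with an estimated range of 18000 nM to 90000 nM.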

Compound 4, half-maximal inhibitory concentration: 25400 nM
Beside the measured number, compound 4's estimate is 1.7-fold (0.22 log units) above it; low and high end bracket the measured number.
By their numbers in this assay, from the lowest: compounds 3, 4, 2 and 1 (each within the scatter of the next, the first and the last beyond it).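

In this assay, rearranging the same atoms on this oxygen into 2-acetoxybutyl, which has 0 hydrogen-bond donors, gives a 1.2-fold higher number from compound 3 to compound 4 (0.09 log units; within the scatter) and so no readable change. The other steps, a 1.7-fold lower number from compound 2 to compound 4 (0.23 log units; within the scatter) and a 1.8-fold lower number from compound 1 to compound 4 (0.25 log units; within the scatter), also stay within the scatter, so compound 4 cannot be told apart from any of the other three, although compound 3 stands apart from compounds 1 and 2. No outside evidence explains this result. On these data alone, whether an amine, a carboxylic acid or a much longer chain on this oxygen would shift the number beyond the scatter stays open.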